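Amide nitrogen substituents on a shared core in MCF7 cytotoxicity

This account rests on a few compounds, and the source may have more. Where it says the series, first, only, none or still open, it means among the compounds named here.

Compound 1 `NNC(=O)Cn1nc(N)c2c(C(F)(F)F)cc(-c3ccccc3)nc21` carries an amino group on the amide-type nitrogen of its side chain. In a functional assay on MCF7 cells (Homo sapiens) for cytotoxicity, read by MTT assay, with a stated time of 24 h (a higher number here means a weaker inhibitor, a lower number a stronger inhibitor), compound 1 gives 35400 nM, the lowest of the two numbers recorded so far. Compound 2 `NCCNC(=O)Cn1nc(N)c2c(C(F)(F)F)cc(-c3ccccc3)nc21`, which differs only at that nitrogen, gives 42900 nM in this assay, and the step of a 1.2-fold higher number from compound 1 to compound 2 (0.08 log units; within the scatter) lies within the scatter. Compound 3 `CC(NC(=O)Cn1nc(N)c2c(C(F)(F)F)cc(-c3ccccc3)nc21)C(=O)O` has not yet been measured; relative to compound 1 the change is 1-carboxyethyl in place of amino on an amide-type nitrogen. Within the data shown here, the one measured step that bears on this, a 1.2-fold higher number from compound 1 to compound 2 (0.08 log units; within the scatter), was also a substitution on the same amide-type nitrogen and showed no shift beyond the scatter. Compound 3 is therefore expected to sit close to compound 1, with a step of about a 1.3-fold higher number from compound 1 to compound 3 (0.10 log units; within the scatter) in this assay. Compound 3 is estimated at 45000 nM, within a range from 15000 nM to 130000 nM.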

Compound 3, half-maximal inhibitory concentration: 19900 nM
Estimate against measurement, compound 3: 2.3-fold (0.35 log units) above; the measured number falls inside the stated range.
By their numbers in this assay, from the lowest: compounds 3, 1 and 2 (each within the scatter of the next, the first and the last beyond it).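

The amide-type nitrogen tolerates a much larger group than the earlier pair showed: 1-carboxyethyl brings five heavy atoms in place of the single one of amino, yet in this assay the step is a 1.8-fold lower number from compound 1 to compound 3 (0.25 log units; within the scatter). Substituents at this nitrogen can nonetheless be told apart, as replacing 2-aminoethyl with 1-carboxyethyl gives a 2.2-fold lower number from compound 2 to compound 3 (0.33 log units; beyond the scatter), a modest step, while compound 1 stays within the scatter of both compound 2 and compound 3. Nothing available here accounts for this difference between the two substituents.

The compounds shown do not separate the carboxylic acid of the 1-carboxyethyl group from its methyl branch. From the compounds shown here alone, how a carboxymethyl group, or a longer chain ending in a carboxylic acid, would read at this nitrogen in this assay also stays open.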